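Nitrile restored as part of a branched chain

The compounds below may be only part of what the source reports. "The series", "measured", "known", "first", "only" and "open" are said of these compounds alone.

For the measured compounds named here, compound 2 `C#CCNC(=O)[C@H](CC(C)C)NC(=O)N1CCOCC1` gives 97000 nM in an assay for inhibition of cathepsin S (Homo sapiens) (on this read-out lower numbers stand for stronger inhibition and higher numbers for weaker inhibition), the highest of the two numbers so far. Compound 1 `CC(C)C[C@H](NC(=O)N1CCOCC1)C(=O)NCC#N` gives 124 nM in this assay. Going by the values given here, the only measured step, a 780-fold higher number from compound 1 to compound 2 (2.89 log units; beyond the scatter), exchanges a cyano for an ethynyl on the saturated chain carbon bound to the amide-type nitrogen.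

Compound 3 `CCCC[C@@H](C#N)NC(=O)[C@H](CC(C)C)NC(=O)N1CCOCC1` differs from compound 2 by 1-cyanopentyl in place of propargyl on an amide-type nitrogen; cut one bond further out, this reads propargylamino to (1-cyanopentyl)amino. The change brings a nitrile back, now within a 1-cyanopentyl group with a defined stereocentre. The step from compound 1 to compound 2 bears on it directly and was large; reversing its nitrile-to-alkyne part argues for a large fall in this assay. Among the compounds with values here, the added chain has no measured counterpart, so the size remains uncertain. The step is expected to be a 490-fold lower number from compound 2 to compound 3 (2.69 log units; beyond the scatter). Compound 3 is therefore estimated at 200 nM, with a range of 30 nM to 2000 nM.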

Compound 3, half-maximal inhibitory concentration: 56 nM
For compound 3 the middle estimate is 3.6-fold (0.55 log units) above the measured one; the measured number falls inside the stated range.
By their numbers in this assay, from the lowest: compound 3; then compound 1; then compound 2.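

In this assay, compound 3 shows that a nitrile on this side of the amide-type nitrogen restores inhibition even when carried within a 1-cyanopentyl group, with a 1700-fold lower number from compound 2 to compound 3 (3.24 log units; beyond the scatter) (large). The position also accepts substitution: butyl in place of hydrogen on a saturated chain carbon bound to an amide-type nitrogen and a triple-bonded carbon causes no loss, and instead gives a 2.2-fold lower number from compound 1 to compound 3 (0.35 log units; beyond the scatter) (modest), so the nitrile does not depend on the unbranched arrangement of compound 1. Nothing available explains either step.

The compounds shown leave open whether methyl, a hexyl chain or a cyclohexyl group in place of butyl would move the number further in either direction. They also leave open how the opposite configuration at the defined stereocentre of the 1-cyanopentyl group would read.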